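The source may report more compounds than this note shows. Statements on the series, on what has been measured and on what is new or still open speak of the compounds shown alone.

Of the compounds shown here, three that share one core have been tested in a functional assay on Caco-2 cells (Homo sapiens) for inhibition, read by MTT assay, with a stated time of 48 h, tested at 10 uM; on this read-out higher numbers stand for more inhibition of growth at the one concentration tested and lower numbers for less inhibition of growth. In it, compound 1 `Cc1cc(=O)c2c(O)c(CN(C)CC(=O)O)c(O)c([C@H]3CCN(C)C[C@H]3O)c2o1` gives 18%, compound 2 `CCOC(=O)N1CCN(Cc2c(O)c([C@H]3CCN(C)C[C@H]3O)c3oc(C)cc(=O)c3c2O)CC1` gives 18%, and compound 3 `Cc1cc(=O)c2c(O)c(CN3CCCC3C(=O)O)c(O)c([C@H]3CCN(C)C[C@H]3O)c2o1` gives 30%, the highest of the three numbers.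

The next compound, compound 4 `Cc1cc(=O)c2c(O)c(CN3CCCCC3)c(O)c([C@H]3CCN(C)C[C@H]3O)c2o1`, differs from compound 3 in one place, on a saturated chain carbon bound to an aromatic carbon: piperidin-1-yl in place of 2-carboxypyrrolidin-1-yl on a saturated chain carbon bound to an aromatic carbon. Swaps at this same place have already given no change at the digits printed from compound 1 to compound 2 (within the scatter), a number 12 percentage points higher from compound 1 to compound 3 (beyond the scatter) and a number 12 percentage points higher from compound 2 to compound 3 (beyond the scatter). So the measured changes here range from none beyond the scatter to modest, but no tested compound carries piperidin-1-yl.

Compound 3, at 30%, sits at the top of this small set, so any shift in this assay seems more likely to be downward, and it may well stay within the scatter. The expected change is a number 7 percentage points lower from compound 3 to compound 4 (within the scatter). For compound 4 the estimated value is 23%, with an expected range from 8% to 42%.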

Compound 4, percent growth inhibition at one concentration: 22%
Compound 4: the middle estimate sits 1 percentage points above what was measured, within the range that was stated.
By their numbers in this assay, from the lowest: compounds 1, 2, 4 and 3 (each within the scatter of the next, the first and the last beyond it).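

In this assay the change to piperidin-1-yl gives a number 8 percentage points lower from compound 3 to compound 4 (within the scatter) and so, with the carboxylic acid gone and a six-membered ring in place of a five-membered one, the reading cannot be told apart from that of the acid-bearing compound 3. Compound 4 carries neither a carboxylic acid nor an ethoxycarbonyl group at this place, yet the steps read a number 4 percentage points higher from compound 2 to compound 4 (within the scatter) and a number 4 percentage points higher from compound 1 to compound 4 (within the scatter) and place it within the scatter of all three earlier compounds, even though compound 3 stands apart from compounds 1 and 2. No measurement is available to explain these numbers.

Losing the carboxylic acid and enlarging the ring happen together here, so their separate contributions remain unknown. A plain pyrrolidin-1-yl group or a 2-carboxypiperidin-1-yl group would pull the two changes apart.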